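Ethoxyphenyl in place of dimethylphenyl on a shared core

This account rests on a few compounds, and the source may have more. Where it says the series, first, only, none or still open, it means among the compounds named here.

Compound 1 `Cc1ccc(NC2=CC(=O)c3nc4n(c3C2=O)[C@H]2OC[C@@H](O)[C@H]2OC4)cc1C` gives 2690 nM in a functional assay on HeLa cells (Homo sapiens) for inhibition, read by sulforhodamine B assay; a lower number here means a stronger inhibitor, a higher number a weaker inhibitor.
Compound 2 `COc1ccc(NC2=CC(=O)c3c(nc4n3[C@H]3OC[C@@H](O)[C@H]3OC4)C2=O)cc1` gives > 8000 nM, a limit of the assay.
Compound 3 `O=C1C(NC2CCCC2)=CC(=O)c2c1nc1n2[C@H]2OC[C@@H](O)[C@H]2OC1` gives > 16000 nM, a limit of the assay.

Compound 1 is the only one of the three with a number; the other two values are limits. Compound 2 sits at the limit of > 8000 nM in this assay, at which 1 of the 3 values shown sits. Compound 3 sits at the limit of > 16000 nM in this assay, at which 1 of the 3 values shown sits. For the measured compounds named here, the one single-point step, a step that the two limits leave unreadable from compound 2 to compound 3, is therefore unreadable.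

Compound 4 `CCOc1ccc(NC2=CC(=O)c3nc4n(c3C2=O)[C@H]2OC[C@@H](O)[C@H]2OC4)cc1` differs from compound 1 by 4-ethoxyphenyl in place of 3,4-dimethylphenyl on an amine nitrogen. Going by the values given here, no measured step covers this change. The closest comparison is compound 2, which carries a 4-methoxyphenyl on an amine nitrogen and reaches only a limit, > 8000 nM. Compound 4 is therefore expected to be weaker than compound 1, estimated at 8000 nM, with a range from 3000 nM to 20000 nM. The step of a 3.0-fold higher number from compound 1 to compound 4 (0.47 log units; beyond the scatter) is thus expected to be a loss beyond the scatter, quite possibly ending at a limit.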

Compound 4, half-maximal inhibitory concentration: 3110 nM
Compound 4: the middle estimate sits 2.6-fold (0.41 log units) above what was measured; low and high end bracket the measured number.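

In this assay, 4-ethoxyphenyl in place of 3,4-dimethylphenyl on the amine nitrogen gives a 1.2-fold higher number from compound 1 to compound 4 (0.06 log units; within the scatter) and so leaves the read-out unchanged, which gives this position a second substituted phenyl group with a readable number. Before this, compound 1 held the only number, while compound 2, with its 4-methoxyphenyl, stood at a limit (> 8000 nM). Nothing shown here bears on why the two numbers match. Going by these compounds, it remains open whether a carboxylic acid or a morpholine on the phenyl ring would hold a number in this range.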